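Changing the outer aromatic ring of compound 2

The source may hold more compounds than are shown below. What is called first, only, known or untested is meant among the compounds shown, and "the series" means these compounds.

Compound 2 `O=S(=O)(Nc1cccc(CO)c1)c1ccc(-c2ccc3cc[nH]c3c2)cc1` gives in a functional assay on J774 cells (Mus musculus) for cytotoxicity, read by resazurin assay, with a stated time of 72 h (a higher number here means a weaker inhibitor, a lower number a stronger inhibitor), 2500 nM, the higher of the two numbers recorded, while compound 1 `O=S(=O)(Nc1cccc(CO)c1)c1ccc(-c2ccccc2)cc1` gives 2200 nM; the gap, a 1.1-fold higher number from compound 1 to compound 2 (0.06 log units; within the scatter), stays within the scatter. Compound 3 `O=S(=O)(Nc1cccc(CO)c1)c1ccc(-c2ccc(Br)cc2F)cc1` differs from compound 2 by 4-bromo-2-fluorophenyl in place of 1H-indol-6-yl on an aromatic carbon. Within the data shown here, the one measured step at this same position, a 1.1-fold higher number from compound 1 to compound 2 (0.06 log units; within the scatter), changed nothing beyond the scatter, so another exchange of this outer ring is expected to shift the number only slightly, about a 1.1-fold lower number from compound 2 to compound 3 (0.04 log units; within the scatter). Compound 3 is therefore estimated at 2300 nM, with a likely range from 1000 nM to 5500 nM.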

Compound 3, half-maximal inhibitory concentration: 1000 nM
Beside the measured number, compound 3's estimate is 2.3-fold (0.36 log units) above it, and the stated range covers the measured number.
By their numbers in this assay, from the lowest: compound 3; then compounds 1 and 2 (each within the scatter of the next).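

In this assay this outer ring position proves less indifferent than the first pair suggested: 4-bromo-2-fluorophenyl in place of 1H-indol-6-yl gives a 2.5-fold lower number from compound 2 to compound 3 (0.40 log units; beyond the scatter) and in place of phenyl gives a 2.2-fold lower number from compound 1 to compound 3 (0.34 log units; beyond the scatter) as well. Both steps are modest, yet they lie beyond the scatter, unlike the exchange of phenyl for 1H-indol-6-yl. No measured evidence on hand bears on this result.

Still open, going by these compounds, is whether the bromine, the fluorine or both go with the lower number, which a phenyl ring carrying only one of them could separate. On these data alone, how an amine or a carboxylic acid on this ring would read also remains unknown.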